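The compounds below may be only part of what the source reports. "The series", "measured", "known", "first", "only" and "open" are said of these compounds alone.

Measured so far:
compound 1 `CCC(CC)(c1ccc(OS(=O)(=O)c2ccc(C)cc2)c(C)c1)c1ccc(OCC(=O)C(C)(C)C)c(OCC(=O)C(C)(C)C)c1` gives 35% in an assay on cells for binding affinity to vitamin D3 receptor (Homo sapiens), read by fluorescence, tested at 1 uM; a lower number here means less inhibition, a higher number more inhibition at the concentration tested (going by the name of the read-out)
compound 2 `CCC(CC)(c1ccc(OCCCCCCO)c(C)c1)c1ccc(OCC(O)C(C)(C)C)c(OCC(O)C(C)(C)C)c1` gives 52%
compound 3 `CCC(CC)(c1ccc(OCCCCCCCO)c(C)c1)c1ccc(OCC(O)C(C)(C)C)c(OCC(O)C(C)(C)C)c1` gives 5%

Compound 2 stands highest of the three; compound 3 lies below it by a number 47 percentage points lower from compound 2 to compound 3 (beyond the scatter), and compound 1 lies lower as well. Compound 4 `CCC(CC)(c1ccc(OS(C)(=O)=O)c(C)c1)c1ccc(OCC(O)C(C)(C)C)c(OCC(O)C(C)(C)C)c1` differs from compound 2 by methylsulfonyl in place of 6-hydroxyhexyl on an oxygen on an aromatic ring. Within the data shown here, no measured step covers this exact change. Among the measured compounds shown here, the one measured step, a number 47 percentage points lower from compound 2 to compound 3 (beyond the scatter), concerns a different alteration on the same aromatic oxygen and shows that the read-out shifts a great deal with changes there. Compound 1, which also carries a sulfonyl group on that oxygen but differs elsewhere too, gives 35%. A downward step is therefore expected, of size a number 22 percentage points lower from compound 2 to compound 4 (beyond the scatter). Compound 4 is estimated at 30%, within a range from 5% to 55%.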

Compound 4, a percentage reported as inhibition, at one concentration (the size of the read-out at that concentration, not a potency): "not active" (no number reported)
For compound 4 the study gives words and no number, so the estimate cannot be set against anything.
By their numbers in this assay, from the lowest: compound 3; then compound 1; then compound 2.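

Among these compounds, compound 4 is reported only in words as not active in this assay and has no number, so no step from compound 2 to compound 4 can be read. The compounds shown leave open how far methylsulfonyl in place of 6-hydroxyhexyl moves the read-out. Nothing given here bears on this result.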